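The compounds below may be only part of what the source reports. "The series", "measured", "known", "first", "only" and "open" are said of these compounds alone.

Compound 2 `COc1ccc(NC2=CC(=O)c3c(nc4n3[C@H]3OC[C@@H](O)[C@H]3OC4)C2=O)cc1` sits in a functional assay on MGC-803 cells (Homo sapiens) for inhibition, read by sulforhodamine B assay (a higher number here means a weaker inhibitor, a lower number a stronger inhibitor), at 2150 nM, the highest of the two numbers shown; compound 1 `Cc1ccc(NC2=CC(=O)c3nc4n(c3C2=O)[C@H]2OC[C@@H](O)[C@H]2OC4)cc1` is nearest with 1420 nM, and the gap between them lies within the scatter. Compound 3 `O=C1C(N2CCCC2)=CC(=O)c2c1nc1n2[C@H]2OC[C@@H](O)[C@H]2OC1` gives only a limit, > 16000 nM. For the measured compounds named here, the single measured step, an at least 7.4-fold higher number from compound 2 to compound 3 (0.87 log units; beyond the scatter), replaced the whole (4-methoxyphenyl)amino group, so it says little about a change to the substituent on the phenyl ring, and its size is only bounded by the limit of > 16000 nM in this assay, at which 1 of the 3 values shown sits. Compound 4 `O=C1C(Nc2ccc(C(F)(F)F)cc2)=CC(=O)c2c1nc1n2[C@H]2OC[C@@H](O)[C@H]2OC1` differs from compound 2 by trifluoromethyl in place of methoxy on an aromatic carbon. Since compound 1 and compound 2 lie within the scatter of each other, no step beyond the scatter is expected here. The expected step is a 1.1-fold lower number from compound 2 to compound 4 (0.03 log units; within the scatter). Compound 4 is therefore estimated at 2000 nM, between 800 nM and 5000 nM.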

Compound 4, half-maximal inhibitory concentration: 1860 nM
Beside the measured number, compound 4's estimate is 1.1-fold (0.03 log units) above it; measured number inside the range.
By their numbers in this assay, from the lowest: compounds 1, 4 and 2 (each within the scatter of the next). At a limit, above all of these: compound 3.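

The swap of methoxy for trifluoromethyl, para to a large group on the phenyl ring, is the first step shown that keeps the aryl amino group and alters only its substituent, and in this assay it gives a 1.2-fold lower number from compound 2 to compound 4 (0.06 log units; within the scatter). This position therefore tolerates a group with more heavy atoms and no hydrogen-bond acceptor without leaving the scatter. Nothing shown here accounts for this step.

Going by these compounds, whether an amine or a carboxylic acid in this place would give a step beyond the scatter stays open.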